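The source may hold more compounds than are shown below. What is called first, only, known or untested is meant among the compounds shown, and "the series" means these compounds.

Measured so far:
compound 1, `O=C(Nc1ccc(C(=O)NO)cc1)Nc1ccc(Cl)c(C(F)(F)F)c1`: 3100 nM
compound 2, `O=C(Nc1ccc2c(c1)CCCN2c1ccc(C(=O)NO)cc1)Nc1ccc(Cl)c(C(F)(F)F)c1`: 3000 nM
compound 3, `O=C(Nc1ccc(NCc2ccc(C(=O)NO)cc2)cc1)Nc1ccc(Cl)c(C(F)(F)F)c1`: 3800 nM

All three numbers come from a functional assay on PC-3 cells (Homo sapiens) for inhibition, read by sulforhodamine B assay, with a stated time of 48 h; a higher number here means a weaker inhibitor, a lower number a stronger inhibitor. Compound 2 shows the lowest number of the three, but its gap to compound 1 and its gap to compound 3 both lie within the scatter, so the three compounds cannot be told apart in this assay. Compound 4, `O=C(Nc1ccc2c(c1)CCCN2Cc1ccc(C(=O)NO)cc1)Nc1ccc(Cl)c(C(F)(F)F)c1`, remains unmeasured. It differs from compound 2 in one place: 4-(hydroxycarbamoyl)benzyl in place of 4-(hydroxycarbamoyl)phenyl on a nitrogen on an aromatic ring in a ring. Within the data shown here, no pair of measured compounds isolates this change. Compound 3 also carries a 4-(hydroxycarbamoyl)benzyl group and gives 3800 nM in this assay, a number within the scatter of the other two. The expected step of a 1.2-fold higher number from compound 2 to compound 4 (0.07 log units; within the scatter) is therefore small, not beyond the scatter in either direction. Compound 4 is estimated at 3500 nM, with a range from 1500 nM to 8000 nM.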

Compound 4, half-maximal inhibitory concentration: 3200 nM
Estimate against measurement, compound 4: 1.1-fold (0.04 log units) above, and the stated range covers the measured number.
By their numbers in this assay, from the lowest: compounds 2, 1, 4 and 3 (each within the scatter of the next).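

In this assay, among these compounds, this pair isolates the change for the first time and gives a 1.1-fold higher number from compound 2 to compound 4 (0.03 log units; within the scatter), so 4-(hydroxycarbamoyl)benzyl in place of 4-(hydroxycarbamoyl)phenyl on this nitrogen has no effect that can be read beyond the scatter. At this position, in the shared core, the two groups cannot be told apart. No evidence on hand bears on this result.

The compounds shown leave open how a longer chain carrying the hydroxycarbamoyl group on this nitrogen would read. Also open, going by these compounds, is whether a carboxylic acid in place of the hydroxycarbamoyl group would give a number of similar size.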